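Lengthening the Nitrogen Substituent in a Cholecystokinin Series

This account rests on a few compounds, and the source may have more. Where it says the series, first, only, none or still open, it means among the compounds named here.

Among the compounds with values here, compound 2 `O=C1C=C(Cl)C(O)(c2ccccc2)N1C1CCCC1` stands as the stronger of the two compounds measured so far in an assay on cell membranes for displacement of a labelled ligand from Cholecystokinin receptor type A (Rattus norvegicus), read by CCK-8 assay, with a stated time of 2 h; on this read-out higher numbers stand for weaker inhibition and lower numbers for stronger inhibition. Compound 2 gives 360 nM, while compound 1 `CN1C(=O)C=C(Cl)C1(O)c1ccccc1` gives 2500 nM. Within the data shown here, the single measured step, a 6.9-fold lower number from compound 1 to compound 2 (0.84 log units; beyond the scatter), shows that a larger group on the ring nitrogen brought a clear gain. Compound 3 `CCCCCCN1C(=O)C=C(Cl)C1(O)c1ccccc1` changes the same position again: hexyl in place of cyclopentyl on an amide-type nitrogen in a ring. Among the measured compounds shown here, the entering group is a chain rather than a ring, and no measured step tells how an open chain compares with a cyclic group here, so the earlier gain cannot simply be carried over. For the measured compounds named here, the one step bearing on this change favours a bulkier group but is silent on ring versus chain. A step within the scatter, or a small loss, is therefore expected, a 1.7-fold higher number from compound 2 to compound 3 (0.22 log units; within the scatter). Compound 3 is expected to give 600 nM, within a range from 150 nM to 2500 nM.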

Compound 3, half-maximal inhibitory concentration: 4500 nM
Compound 3: the middle estimate sits 7.5-fold (0.88 log units) below what was measured; measured number above the stated range.
By their numbers in this assay, from the lowest: compound 2; then compounds 1 and 3 (each within the scatter of the next).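

In this assay, the number of atoms alone does not decide the outcome at this nitrogen: hexyl holds six carbons against the five of cyclopentyl, yet the swap gives a 13-fold higher number from compound 2 to compound 3 (1.10 log units; beyond the scatter) and the gain seen with the ring does not carry over to the open chain. Set against the methyl group, the hexyl chain gives a 1.8-fold higher number from compound 1 to compound 3 (0.26 log units; within the scatter) and so compound 1 and compound 3 cannot be told apart, which leaves cyclopentyl as the only one of the three groups that stands clear of the others. Nothing measured here explains why the ring and the chain differ.

As far as these compounds go, it remains open whether a shorter chain such as butyl would fall nearer compound 2 or compound 3. From the compounds shown here alone, it also remains open whether a larger ring such as cyclohexyl would keep the gain seen with cyclopentyl.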